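The source may hold more compounds than are shown below. What is called first, only, known or untested is meant among the compounds shown, and "the series" means these compounds.

Compound 1 `CCCCCc1ccc(C#Cc2cn(C/C=C\CN3C(=O)c4ccccc4C3=O)c(=O)[nH]c2=O)cc1` is a Z-configured member of the set. In a functional assay on SW-620 cells (Homo sapiens) for antiproliferative activity, read by MTT assay, with a stated time of 3 days (on this read-out lower numbers stand for stronger inhibition and higher numbers for weaker inhibition), compound 1 gives only a limit, > 100000 nM, and no number. Its E-configured counterpart compound 2 `CCCCCc1ccc(C#Cc2cn(C/C=C/CN3C(=O)c4ccccc4C3=O)c(=O)[nH]c2=O)cc1` gives 30000 nM, so an at least 3.3-fold lower number from compound 1 to compound 2 (0.52 log units; beyond the scatter); compound 3 `O=C1c2ccccc2C(=O)N1C/C=C/Cn1cc(C#CCCc2ccccc2)c(=O)[nH]c1=O` gives 11000 nM, and a 2.7-fold lower number from compound 2 to compound 3 (0.44 log units; beyond the scatter). Compound 4 `CCCCc1ccc(C#Cc2cn(C/C=C\CN3C(=O)c4ccccc4C3=O)c(=O)[nH]c2=O)cc1` differs from compound 1 by hydrogen in place of methyl on a saturated chain carbon, four bonds along the chain from an aromatic carbon. Neither measured step touches the pentyl chain: one concerns configuration, the other phenethyl in place of 4-pentylphenyl, so neither bears directly on this change. With compound 1 at a limit, no step beyond the scatter is expected, and compound 4 is estimated at 100000 nM (range 30000 nM to 300000 nM), which would mean a number no higher from compound 1 to compound 4 (the limit leaves the size open).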

Compound 4, half-maximal inhibitory concentration: > 100000 nM
Compound 4 ended at the assay's limit; the forecaster's own chance of this, stated with the estimate: 70%; the middle value lies on the limit itself.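

Compounds 1 and 4 both give only limits and no numbers, so the step between them cannot be read. The compounds shown leave open whether hydrogen in place of methyl on that chain carbon changes antiproliferative activity at all.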